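The source may hold more compounds than are shown below. What is called first, only, known or untested is meant among the compounds shown, and "the series" means these compounds.

Measured in a functional assay (Cardiac muscle cell, Rattus norvegicus, strain Sprague-Dawley) for inhibition, read by LDH release, with a stated time of 6 h; a lower number here means that less compound is needed, a higher number that more compound is needed for the effect:
- compound 1 `COC(=O)c1oc2ccccc2c1NC(=O)COc1ccc(Br)cc1`: 1180 nM
- compound 2 `COC(=O)c1oc2ccccc2c1NC(=O)CSc1ccccn1`: 653 nM
- compound 3 `COC(=O)c1oc2cccc(Cl)c2c1NC(=O)CCSc1ccccn1`: 557 nM

Not yet measured: compound 4 `COC(=O)c1oc2ccccc2c1NC(=O)CCSc1ccccn1`.

Of the three numbers, that of compound 3 lies within the scatter of compound 2 and has the lower number against compound 1, by a gap beyond the scatter. Compound 4 follows from compound 3 by a single change: hydrogen in place of chloro on an aromatic carbon.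

Among the measured compounds shown here, no measured pair isolates this change. For the measured compounds named here, the only measured step, a 1.8-fold lower number from compound 1 to compound 2 (0.26 log units; within the scatter), concerns (pyridin-2-yl)sulfanyl in place of 4-bromophenoxy, which is a different change in a different place, and it stays within the scatter. It therefore gives only weak guidance on size. The values of compound 2 at 653 nM and compound 3 at 557 nM also lie within the scatter of each other. With so few data, no step beyond the scatter is expected in this assay, and no direction can be favoured. The expected change is a 1.1-fold higher number from compound 3 to compound 4 (0.03 log units; within the scatter), which is estimated to remain within the scatter. For compound 4 the estimated value is 600 nM, with an expected range from 280 nM to 1250 nM.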

Compound 4, half-maximal effective concentration: 929 nM
Estimate against measurement, compound 4: 1.5-fold (0.19 log units) below; the measured number falls inside the stated range.
By their numbers in this assay, from the lowest: compounds 3, 2, 4 and 1 (each within the scatter of the next, the first and the last beyond it).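

In this assay, among the compounds shown here, the pair gives the first direct reading of hydrogen in place of chloro on an aromatic carbon of the six-membered aromatic ring of carbon only: a 1.7-fold higher number from compound 3 to compound 4 (0.22 log units; within the scatter) shows that this single atom change, with one chlorine leaving and no heavy atom entering, stays inside the usual spread of the assay. On the side chain, the ((pyridin-2-yl)sulfanyl)methyl group in place of (pyridin-2-yl)sulfanyl gives a 1.4-fold higher number from compound 2 to compound 4 (0.15 log units; within the scatter) and the same group in place of 4-bromophenoxy gives a 1.3-fold lower number from compound 1 to compound 4 (0.10 log units; within the scatter), so neither chain replacement separates from its parent, and the gap between compound 1 and compound 3 cannot be assigned to any one of these changes. Nothing available explains these steps or links them to a property of either group.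

As far as these compounds go, the chloro position is read through a single pair, so it remains open how a methoxy, a fluoro or an amine on that same aromatic carbon would read in this assay. Also open, from the compounds shown here alone, are a longer chain between the amide carbonyl and the sulfur, and a carboxylic acid in place of the methyl ester on the shared core.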